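Trading 4-cyanophenyl for thiophen-2-yl on the shared core

This account rests on a few compounds, and the source may have more. Where it says the series, first, only, none or still open, it means among the compounds named here.

Of the compounds shown here, two sharing one core have been measured in a functional assay on MKN-45 cells (Homo sapiens) for inhibition, with a stated time of 72 h; a lower number here means a stronger inhibitor, a higher number a weaker inhibitor. Compound 1 `COc1ccc(S(=O)(=O)N2CCc3cccc(-c4cccnc4)c32)cc1` gives 68.5 nM, and compound 2 `COc1ccc(S(=O)(=O)N2CCc3cccc(-c4ccc(C#N)cc4)c32)cc1` gives 17.2 nM, the lower of the two numbers. The next analogue, compound 3 `COc1ccc(S(=O)(=O)N2CCc3cccc(-c4cccs4)c32)cc1`, carries thiophen-2-yl in place of 4-cyanophenyl on an aromatic carbon. For the measured compounds named here, only one measured step bears on this change: a 4.0-fold lower number from compound 1 to compound 2 (0.60 log units; beyond the scatter), a modest swap of one aromatic group for another on an aromatic carbon. Going by the values given here, no thiophene analogue has been measured, so that step offers only a guide to size. A step of similar or smaller size is expected, towards a higher number, given the low standing of compound 2 at 17.2 nM. The expected change is a 2.3-fold higher number from compound 2 to compound 3 (0.37 log units; beyond the scatter). For compound 3 the estimated value is 40 nM, with an expected range from 12 nM to 130 nM.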

Compound 3, half-maximal inhibitory concentration: 165 nM
Beside the measured number, compound 3's estimate is 4.1-fold (0.62 log units) below it; the whole stated range lies below it.
By their numbers in this assay, from the lowest: compound 2; then compound 1; then compound 3.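

In this assay, the change to thiophen-2-yl gives a 9.6-fold higher number from compound 2 to compound 3 (0.98 log units; beyond the scatter), a larger move at this position than the earlier swap of pyridin-3-yl for 4-cyanophenyl had shown. Thiophen-2-yl also falls behind pyridin-3-yl, with a 2.4-fold higher number from compound 1 to compound 3 (0.38 log units; beyond the scatter), so among these three compounds both groups built on a six-membered aromatic ring give lower numbers than the five-membered one, and none of the three goes against this. Nothing available explains this order.

From the compounds shown here alone, it remains open whether the low number of compound 2 belongs to the nitrile or to the six-membered ring itself, a question plain phenyl would help to settle. Furan-2-yl or thiophen-3-yl would show whether the number of compound 3 follows the ring size, the sulfur or the point of attachment.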